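Swapping the amide ring of compound 3 for an azetidine

A few compounds are considered here, and "the series" means these few. Any claim that something is new, unique, unknown or untested is made for them only; others in the source may bear on it.

In an ADME assay on microsomes from liver (Mus musculus, strain CD-1) for metabolic stability, read by LC-MS, tested at 2 uM (a higher number here means that the compound lasts longer, a lower number that the compound disappears faster), compound 1 `Cn1cc(CNC(=O)c2ccncc2Nc2cc(-c3ccc4ccn(C)c4c3)c3nccnc3c2)cn1` gives 0.267 h, and compound 3 `CN1CC(NC(=O)c2ccncc2Nc2cc(-c3ccc4ccn(C)c4c3)c3nccnc3c2)CCC1=O` gives 0.75 h, the higher of the two actual numbers. Compound 2 `CN1CCC(NC(=O)c2ccncc2Nc2cc(-c3ccc4ccn(C)c4c3)c3nccnc3c2)CC1` reads > 1 h, which is a limit of the assay and not a number. Compound 4 `CN1CC(NC(=O)c2ccncc2Nc2cc(-c3ccc4ccn(C)c4c3)c3nccnc3c2)C1` carries 1-methylazetidin-3-yl in place of 1-methyl-6-oxopiperidin-3-yl on an amide-type nitrogen. Putting a non-aromatic ring in place of (1-methyl-1H-pyrazol-4-yl)methyl gave an at least 3.7-fold higher number from compound 1 to compound 2 (0.57 log units; beyond the scatter) and a 2.8-fold higher number from compound 1 to compound 3 (0.45 log units; beyond the scatter). Exchanging one such ring for another gave only an at least 1.3-fold lower number from compound 2 to compound 3 (0.12 log units; that floor lies within the scatter), so the same kind of exchange is expected to stay within the scatter. The expected step is a 1.1-fold higher number from compound 3 to compound 4 (0.03 log units; within the scatter). For compound 4 the estimated half-life is 0.8 h. The expected range for compound 4 runs from 0.35 h to 1.8 h.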

Compound 4, half-life: > 1 h
Compound 4: only a limit was reported; the forecaster's own chance of this, stated with the estimate: 35%; middle value at least 1.2-fold (0.09 log units) away from the limit.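

In this assay, the gain over (1-methyl-1H-pyrazol-4-yl)methyl on the amide-type nitrogen survives when the non-aromatic ring shrinks to four members (an at least 3.7-fold higher number from compound 1 to compound 4 (0.57 log units; beyond the scatter)). Replacing 1-methyl-6-oxopiperidin-3-yl shows no loss (an at least 1.3-fold higher number from compound 3 to compound 4 (0.12 log units; that floor lies within the scatter)), so this position accepts a smaller ring without the carbonyl. The step between compound 2 and compound 4 cannot be read, because both sit at a limit: the limit of > 1 h in this assay, at which 2 of the 4 values shown sit.

Going by these compounds, whether 1-methylpyrrolidin-3-yl or an open-chain amine such as 2-(dimethylamino)ethyl behaves the same stays open. So does how far compound 2 and compound 4 lie past that limit.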